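One Hydroxyl Group Added to Compound 2

The compounds below may be only part of what the source reports. "The series", "measured", "known", "first", "only" and "open" are said of these compounds alone.

Measured compounds:
Compound 1, `Fc1cc(C(F)(F)F)ccc1Nc1nc2nonc2nc1Nc1ccc(C(F)(F)F)cc1F`: in an assay on mitochondria from L6 cells (Rattus norvegicus) for activation, with a stated time of 90 min (on this read-out lower numbers stand for an effect already at smaller amounts and higher numbers for an effect only at larger amounts of compound), compound 1 gives < 1000 nM, and this value is a limit of the assay rather than a number.
Compound 2, `Fc1cccc(Nc2nc3nonc3nc2Nc2ccccc2F)c1`: in this assay compound 2 gives 190 nM.

Compound 2 therefore holds the only number shown in this assay; the other value shown is the limit described in the limit of < 1000 nM in this assay, at which 1 of the 2 values shown sits, so compound 2 cannot be placed above or below compound 1 with any confidence. Among the compounds with values here, no pair of measured compounds differs in one place only, so no measured step is available to guide the next change.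

Compound 3, `Oc1ccc(F)c(Nc2nc3nonc3nc2Nc2ccccc2F)c1`, is not yet measured. It differs from compound 2 by 2-fluoro-5-hydroxyphenyl in place of 3-fluorophenyl on a nitrogen on an aromatic ring. Within the data shown here, with no measured step to lean on, the expected step from compound 2 to compound 3 in this assay is a 1.1-fold higher number from compound 2 to compound 3 (0.02 log units; within the scatter), which stays within the usual scatter, with no clear direction. Compound 3 is thus expected to give about 200 nM in this assay, with a range from 60 nM to 650 nM.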

Compound 3, half-maximal effective concentration: 30000 nM
The estimate for compound 3 lay 150-fold (2.18 log units) below the measured number; the whole stated range lies below it.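

In this assay, putting 2-fluoro-5-hydroxyphenyl in place of 3-fluorophenyl on a nitrogen on an aromatic ring gives a 160-fold higher number from compound 2 to compound 3 (2.20 log units; beyond the scatter), a large step beyond the scatter. The earlier compounds shown here offered one number, one limit and no pair differing in one place, so they could not show how this place responds to change; this step shows that a single exchange here can shift the effect to much larger amounts of compound. Nothing shown gives a reason for a step of this size.

As far as these compounds go, the step joins two changes in one, since the hydroxyl group enters while the fluorine also stands differently in the two group names, so it remains open whether the hydroxyl group, the fluorine's new place or the two together account for the much higher number. Also open, from the compounds shown here alone, is how this place would respond to a methoxy group, an amine or a carboxylic acid in place of the hydroxyl group, and whether a hydroxyl group alone on 3-fluorophenyl would give a step of similar size.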